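The compounds below may be only part of what the source reports. "The series", "measured", "known", "first", "only" and "open" are said of these compounds alone.

Three compounds share a core and differ in what hangs from an oxygen on its aromatic ring. Compound 1 `CC(C)=CCOc1c(C)c(C)c2c(c1C)CCC(C)(COc1ccc(/C=C3\SC(=O)NC3=O)cc1-c1ccc(F)cc1)O2` gives 87% in a functional assay on MCF7 cells (Homo sapiens), tested at 2.5 uM; a lower number here means a stronger effect, a higher number a weaker effect of the compound at the concentration tested. Compound 2 `Cc1c(C)c2c(c(C)c1OC/C=C/c1ccccc1)CCC(C)(COc1ccc(/C=C3\SC(=O)NC3=O)cc1)O2` gives 92% in this assay, and compound 3 `Cc1c(C)c2c(c(C)c1OCc1ccccc1)CCC(C)(COc1ccc(/C=C3\SC(=O)NC3=O)cc1)O2` gives 85%; the values of compound 1 and compound 2 both lie within the scatter of the value of compound 3. Going by the values given here, the one step with a single change, a number 7 percentage points lower from compound 2 to compound 3 (within the scatter), swapped groups at the very position that now changes again.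

Compound 4 `CC(C)=CCOc1c(C)c(C)c2c(c1C)CCC(C)(COc1ccc(/C=C3\SC(=O)NC3=O)cc1)O2` differs from compound 3 in that (2-methylprop-1-en-1-yl in place of phenyl on a saturated chain carbon bound to an oxygen on an aromatic ring). The step from compound 2 to compound 3 at this position stayed within the scatter, and compound 1, which also carries the 2-methylprop-1-en-1-yl group at this place along with a further group elsewhere, sits within the scatter of compound 3. Compound 4 is therefore expected to show a step of a number 2 percentage points higher from compound 3 to compound 4 (within the scatter), none beyond the scatter. Compound 4 is estimated at 87%, between 76% and 98%.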

Compound 4, a percentage reported as activity, at one concentration (the size of the read-out at that concentration, not a potency): 76%
Estimate against measurement, compound 4: 11 percentage points above; low and high end bracket the measured number.
By their numbers in this assay, from the lowest: compounds 4, 3, 1 and 2 (each within the scatter of the next, the first and the last beyond it).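

In this assay, going by these compounds alone, the change to 2-methylprop-1-en-1-yl on a saturated chain carbon bound to an oxygen on an aromatic ring gives the first step at this position that clears the scatter, a number 16 percentage points lower from compound 2 to compound 4 (beyond the scatter), while the step against the phenyl group, a number 9 percentage points lower from compound 3 to compound 4 (within the scatter), does not. The result also shows that the aromatic carbon carrying 4-fluorophenyl in compound 1 counts, since hydrogen there gives a number 11 percentage points lower from compound 1 to compound 4 (beyond the scatter), a modest step with the same group on the oxygen. Nothing available explains either step.

On these data alone, whether a saturated chain such as 3-methylbutyl on the oxygen would read like compound 4 remains open. So does whether a smaller group such as methyl or fluorine on that aromatic carbon would read like compound 1 or like compound 4.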